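The source may hold more compounds than are shown below. What is called first, only, known or untested is meant among the compounds shown, and "the series" means these compounds.

Two compounds share one core and differ only in the group carried on an aromatic nitrogen. Compound 1 `Cc1ccccc1-n1cc(-c2cccc(NS(=O)(=O)c3c[nH]c(=O)[nH]c3=O)c2)nn1` in a functional assay on OVCAR-3 cells (Homo sapiens) for antiproliferative activity, read by MTT assay, with a stated time of 24 h (on this read-out higher numbers stand for weaker inhibition and lower numbers for stronger inhibition), gives 6230 nM. Compound 2 `Cc1ccc(-n2cc(-c3cccc(NS(=O)(=O)c4c[nH]c(=O)[nH]c4=O)c3)nn2)cc1` in this assay gives 3540 nM. Of these two numbers, compound 2 has the lower one, yet the step of a 1.8-fold lower number from compound 1 to compound 2 (0.25 log units; within the scatter) shows that the two values cannot be told apart with confidence.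

Compound 3 `O=c1[nH]cc(S(=O)(=O)Nc2cccc(-c3cn(-c4ccccc4F)nn3)c2)c(=O)[nH]1` is not yet measured. It differs from compound 2 in one place: 2-fluorophenyl in place of 4-methylphenyl on an aromatic nitrogen. Among the measured compounds shown here, the only measured step, from compound 1 to compound 2, also changed this same phenyl group, moving a methyl between two positions on it, and a 1.8-fold lower number from compound 1 to compound 2 (0.25 log units; within the scatter) shows that this left the number within the scatter. That step bears on the present change only loosely, since here a methyl is replaced by a fluorine and the position moves as well, so nothing measured points in a clear direction.

The expectation for compound 3 is therefore a step of a 1.3-fold higher number from compound 2 to compound 3 (0.10 log units; within the scatter), no more than the scatter, placing compound 3 at an estimated 4500 nM with a range from 1500 nM to 14000 nM.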

Compound 3, half-maximal inhibitory concentration: 12500 nM
Estimate against measurement, compound 3: 2.8-fold (0.44 log units) below; measured number inside the range.
By their numbers in this assay, from the lowest: compounds 2, 1 and 3 (each within the scatter of the next, the first and the last beyond it).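

In this assay the phenyl group on the aromatic nitrogen now gives its first step beyond the scatter, with a 3.5-fold higher number from compound 2 to compound 3 (0.55 log units; beyond the scatter) for 2-fluorophenyl in place of 4-methylphenyl, although the step is only modest in size. Where the ring substituent stays at the same place and only fluoro replaces methyl, the reading is a 2.0-fold higher number from compound 1 to compound 3 (0.30 log units; within the scatter) and so 2-fluorophenyl and 2-methylphenyl cannot be told apart, which means the one clear step comes from a swap that alters both the substituent and its place on the ring. No measurement at hand explains why the number shifts between these groups.

With the substituent and its place changed together in the one clear step, the compounds shown cannot say which of the two matters more. They also leave open how this phenyl group would behave with no substituent at all, or carrying a different group such as a methoxy, an amine or a carboxylic acid, since only methyl and fluoro appear on it here.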